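A few compounds are considered here, and "the series" means these few. Any claim that something is new, unique, unknown or untested is made for them only; others in the source may bear on it.

Measured compounds:
compound 1 `CCc1nc(Cl)c(C2C(C(=O)OC)=C(C)NC(C)=C2C(=O)OC)[nH]1` — 0.596 nM
compound 2 `CCOC(=O)C1=C(C)NC(C)=C(C(=O)OCC)C1c1[nH]c(CC)nc1Cl` — 0.158 nM
compound 3 `CCc1nc(Cl)c(C2C(C(=O)OC)=C(C)NC(C)=C2C(=O)OCc2ccccc2)[nH]1` — 1.75 nM

In an assay on ileum for inhibition of Voltage-dependent L-type calcium channel subunit alpha-1C (Cavia porcellus) (on this read-out lower numbers stand for stronger inhibition and higher numbers for weaker inhibition), compound 2 gives the lowest number of the three, with compound 1 nearest and compound 3 furthest away. Compound 4 `CCOC(=O)C1=C(C)NC(C)=C(C(=O)OC(C)(C)C)C1c1[nH]c(CC)nc1Cl` differs from compound 2 by tert-butyl in place of ethyl on an oxygen next to a carbonyl group. Among the measured compounds shown here, the only comparable step seen so far, a 2.9-fold higher number from compound 1 to compound 3 (0.47 log units; beyond the scatter), also made a group on an oxygen next to a carbonyl group larger, and the number rose modestly. Because of a 2.9-fold higher number from compound 1 to compound 3 (0.47 log units; beyond the scatter), a larger group entering at the same kind of place in compound 2 is expected to raise the number by a similar, modest amount rather than leave it within the scatter. Compound 4 is therefore expected to give about 0.4 nM, most likely between 0.12 nM and 1.3 nM. This estimate means a 2.5-fold higher number from compound 2 to compound 4 (0.40 log units; beyond the scatter).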

Compound 4, half-maximal inhibitory concentration: 99.8 nM
Compound 4: middle estimate off by 250-fold (2.40 log units), on the low side, outside the stated range (above it).
By their numbers in this assay, from the lowest: compound 2; then compound 1; then compound 3; then compound 4.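

In this assay, tert-butyl in place of ethyl on an oxygen next to a carbonyl group gives a 630-fold higher number from compound 2 to compound 4 (2.80 log units; beyond the scatter) and so costs far more than the phenyl step, a 2.9-fold higher number from compound 1 to compound 3 (0.47 log units; beyond the scatter) in the same read-out. This place therefore does not treat all larger groups alike: the identity of the group matters, not merely that it grows. Nothing measured here explains the jump. Still open, on these data alone, is how the number changes across intermediate groups, such as isopropyl or a longer chain like butyl on this oxygen.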